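Ring size at the saturated chain carbon in the shared core

A few compounds are considered here, and "the series" means these few. Any claim that something is new, unique, unknown or untested is made for them only; others in the source may bear on it.

Compound 3, `Nc1nc(-c2ccc(Cl)o2)nc2sc(CN3CC=CCC3)cc12`, gives 190 nM in an assay on CHO-K1 cells for antagonist activity at adenosine receptor A1 (Homo sapiens), read by a beta-galactosidase reporter, with stated times of 15 min and 6 h (on this read-out higher numbers stand for weaker inhibition and lower numbers for stronger inhibition), the lowest of the three numbers in hand. Compound 1, `Nc1nc(-c2ccco2)nc2sc(CN3CC=CC3)cc12`, gives 290 nM in this assay, a value within the scatter of that of compound 3. For the measured compounds named here, compound 2, `Nc1nc(-c2ccc(Cl)o2)nc2sc(CN3CCCCCC3)cc12`, gives 1420 nM in this assay, and the move a 7.5-fold lower number from compound 2 to compound 3 (0.87 log units; beyond the scatter) is the only measured step that bears directly on the question of ring size at this position. Compound 4, `Nc1nc(-c2ccc(Cl)o2)nc2sc(CN3CC=CC3)cc12`, is not yet measured in this assay; it differs from compound 3 by a group of 5 heavy atoms (4 carbon, 1 nitrogen; one five-membered non-aromatic ring with 1 hetero atom) in place of a group of 6 heavy atoms (5 carbon, 1 nitrogen; one six-membered non-aromatic ring with 1 hetero atom), on a saturated chain carbon bound to an aromatic carbon. Going by the values given here, compound 4 shares the five-membered ring of compound 1 and the chlorine-bearing furan of compound 3; no single step between compound 1 and compound 3 can be stated, since they differ in two places, but their values sit within the scatter of one another. The measured step from the seven-membered to the six-membered ring favoured the smaller ring, yet the values of compound 1 and compound 3 give no sign that a further reduction in ring size moves the number beyond the scatter. For compound 4 the expected step of a 1.3-fold higher number from compound 3 to compound 4 (0.12 log units; within the scatter) is therefore small, and the estimate for compound 4 is 250 nM in this assay, with a range from 100 nM to 600 nM.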

Compound 4, inhibition constant: 780 nM
For compound 4 the middle estimate is 3.1-fold (0.49 log units) below the measured one; the whole stated range lies below it.
By their numbers in this assay, from the lowest: compounds 3 and 1 (each within the scatter of the next); then compounds 4 and 2 (each within the scatter of the next).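

With only the ring on the saturated chain carbon bound to an aromatic carbon changing, the six-membered ring now stands apart on both sides in this assay: the step down in ring size is a 4.1-fold higher number from compound 3 to compound 4 (0.61 log units; beyond the scatter), the step up in ring size is a 7.5-fold lower number from compound 2 to compound 3 (0.87 log units; beyond the scatter), and the outer pair gives a 1.8-fold lower number from compound 2 to compound 4 (0.26 log units; within the scatter). The five-membered ring also gives a reading of a single change elsewhere in the molecule, chloro in place of hydrogen on an aromatic carbon, at a 2.7-fold higher number from compound 1 to compound 4 (0.43 log units; beyond the scatter), so this ring position is not the only place in the series where one change moves the number beyond the scatter. No accompanying data bear on why either step occurs.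

Compound 2 has no double bond in its ring while compound 3 and compound 4 each have one, so ring size and the double bond remain unseparated in the steps from compound 2, and a saturated piperidine or pyrrolidine ring or an open-chain diethylamino group at the same carbon would address this. Going by these compounds, the chloro step is known only with the five-membered ring, and its size with the six-membered ring stays open.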